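A few compounds are considered here, and "the series" means these few. Any claim that something is new, unique, unknown or untested is made for them only; others in the source may bear on it.

Compound 2 `O=C(Nc1cccc(Cl)c1)c1ccccc1O` gives 37000 nM in an ADME assay on HEK293 cells (Homo sapiens) for cytotoxicity, read by reporter gene assay and resazurin assay, with a stated time of 48 h (on this read-out lower numbers stand for higher toxicity in this test and higher numbers for lower toxicity in this test), the larger of the two figures so far, but compound 1 `O=C(Nc1ccccc1)c1cc(Br)ccc1O` gives 35000 nM in this assay and the two lie within the scatter, so no order between them can be read. Compound 3 `O=C(Nc1cccc(Cl)c1)c1cc(Br)ccc1O` has not been measured; relative to compound 2 it carries bromo in place of hydrogen on an aromatic carbon. For the measured compounds named here, no measured step of this kind exists in the set. Because compound 1 already carries bromo and gives 35000 nM, the expected step from compound 2 to compound 3 in this assay is a 1.5-fold lower number from compound 2 to compound 3 (0.17 log units; within the scatter), small and toward a lower number, not clearly beyond the scatter. Compound 3 is estimated at 25000 nM, range 10000 nM to 55000 nM.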

Compound 3, half-maximal cytotoxic concentration: 15000 nM
Compound 3: the middle estimate sits 1.7-fold (0.22 log units) above what was measured, within the range that was stated.
By their numbers in this assay, from the lowest: compound 3; then compounds 1 and 2 (each within the scatter of the next).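

In this assay, bromo in place of hydrogen on the aromatic carbon para to a hydroxy group gives a 2.5-fold lower number from compound 2 to compound 3 (0.39 log units; beyond the scatter) when chloro is present, and chloro in place of hydrogen gives a 2.3-fold lower number from compound 1 to compound 3 (0.37 log units; beyond the scatter) when bromo is present. For the compounds shown here, compound 3, which carries both halogens, is thus the one compound here that stands apart from the other two, while compounds 1 and 2 each carry one and cannot be ordered. No available evidence bears on the origin of these steps. Still open, going by these compounds, is how an amine or a carboxylic acid on this same carbon would compare with bromo.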